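This account rests on a few compounds, and the source may have more. Where it says the series, first, only, none or still open, it means among the compounds named here.

Compound 1 `O=C(NCc1cn(Cc2ccc(F)cc2)nn1)c1cn(-c2ccccc2)nc1-c1ccc(Cl)cc1` gives 570 nM in a functional assay on MCF7 cells (Homo sapiens) for antiproliferative activity, read by sulforhodamine B assay, with a stated time of 48 h; a lower number here means a stronger inhibitor of growth, a higher number a weaker inhibitor of growth.
Compound 2 `O=C(NCc1cn(Cc2ccc(Cl)cc2)nn1)c1cn(-c2ccccc2)nc1-c1ccc(Cl)cc1` gives 28800 nM in this assay.
Compound 3 `O=C(NCc1cn(Cc2ccc(C(F)(F)F)cc2)nn1)c1cn(-c2ccccc2)nc1-c1ccc(Cl)cc1` gives 4900 nM in this assay.

Among these three numbers compound 3 stands second highest: its nearest neighbour is compound 2, reached by a 5.9-fold lower number from compound 2 to compound 3 (0.77 log units; beyond the scatter), and its furthest is compound 1, reached by an 8.6-fold higher number from compound 1 to compound 3 (0.93 log units; beyond the scatter). The three compounds share one core and differ only in the group on the saturated chain carbon bound to an aromatic nitrogen. Compound 4 `COc1ccc(Cn2cc(CNC(=O)c3cn(-c4ccccc4)nc3-c3ccc(Cl)cc3)nn2)cc1OC` continues that series with 3,4-dimethoxyphenyl in place of 4-(trifluoromethyl)phenyl on a saturated chain carbon bound to an aromatic nitrogen. Going by the values given here, no measured step exchanges the group at that place for a dimethoxyphenyl, so the measured steps bear on compound 4 only in showing how much the number moves when that group is varied: a 51-fold higher number from compound 1 to compound 2 (1.70 log units; beyond the scatter) and an 8.6-fold higher number from compound 1 to compound 3 (0.93 log units; beyond the scatter) were both beyond the scatter, the first large, the second modest. A step beyond the scatter in this assay is therefore expected from compound 3 to compound 4 as well, but the three numbers give no ground for its direction, so the estimate is kept near compound 3 with a wide range. Compound 4 is expected to give 3000 nM in this assay, within 400 nM to 25000 nM. The expected step is a 1.6-fold lower number from compound 3 to compound 4 (0.21 log units; within the scatter).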

Compound 4, concentration for 50% growth inhibition: > 100000 nM
Compound 4 ended at the assay's limit; the forecaster's own chance of this, stated with the estimate: 10%; middle value at least 33-fold (1.52 log units) away from the limit.
By their numbers in this assay, from the lowest: compound 1; then compound 3; then compound 2. At a limit, above all of these: compound 4.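

In this assay compound 4 gives > 100000 nM, which is a limit of the assay and not a number: the limit of > 100000 nM in this assay, at which 1 of the 4 values shown sits.

Even so, the steps to compound 4 can be read as lower bounds on the change: an at least 20-fold higher number from compound 3 to compound 4 (1.30 log units; beyond the scatter), an at least 3.4-fold higher number from compound 2 to compound 4 (0.54 log units; beyond the scatter) and an at least 170-fold higher number from compound 1 to compound 4 (2.24 log units; beyond the scatter). Going by these compounds alone, the earlier compounds showed only that the number moves widely among 4-fluorophenyl, 4-chlorophenyl and 4-(trifluoromethyl)phenyl, whereas compound 4 shows that 3,4-dimethoxyphenyl at this place, on a saturated chain carbon bound to an aromatic nitrogen, lies beyond all three and takes growth inhibition out of the range that this assay can read.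

The compounds shown leave open whether this loss needs both methoxy groups, as a lone 4-methoxyphenyl or 3-methoxyphenyl group would tell, and how far compound 4 lies past the limit. They also leave open how an unsubstituted phenyl, a 4-hydroxyphenyl or a 4-(dimethylamino)phenyl group at the same place would compare with compound 1 and compound 4.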